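The source may report more compounds than this note shows. Statements on the series, on what has been measured and on what is new or still open speak of the compounds shown alone.

Measured so far in a physicochemical assay for solubility, at pH 7; a lower number here means a less soluble compound, a higher number a more soluble compound:
compound 1 `O=C(Nc1ncc(Cc2ccccn2)s1)C1CCCCC1` gives 340 ug/mL
compound 2 `O=C(Nc1ncc(Cc2ccncc2)s1)C1CCCCC1` gives 350 ug/mL

Compound 2, with 350 ug/mL in this assay, stands level with compound 1 within the scatter, so the two cannot be ranked. Compound 3 `O=C(Nc1ncc(Cc2cccnc2)s1)C1CCCCC1` has the same atoms as compound 2, joined differently, with pyridin-3-yl in place of pyridin-4-yl on a saturated chain carbon bound to an aromatic carbon. Among the measured compounds shown here, only one measured step bears on this change. That step, a 1.0-fold higher number from compound 1 to compound 2 (0.01 log units; within the scatter) for a swap of pyridin-2-yl for pyridin-4-yl at the same place, stays within the scatter. No step beyond the scatter is therefore expected here, and the estimated step is a 1.0-fold lower number from compound 2 to compound 3 (0.01 log units; within the scatter) in this assay for this exchange. Compound 3 is expected at 340 ug/mL (estimated range 190 ug/mL to 600 ug/mL).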

Compound 3, solubility: 340 ug/mL
Compound 3: the middle estimate sits on the measured number at the digits printed; the range from low to high includes it.
By their numbers in this assay, from the lowest: compounds 1, 3 and 2 (each within the scatter of the next).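

In this assay, pyridin-3-yl in place of pyridin-4-yl gives a small step (a 1.0-fold lower number from compound 2 to compound 3 (0.01 log units; within the scatter)), and pyridin-3-yl in place of pyridin-2-yl gives none (no change at the digits printed from compound 1 to compound 3 (within the scatter)). All three pyridinyl attachments on a saturated chain carbon bound to an aromatic carbon can now be set side by side, and compound 1, compound 2 and compound 3 cannot be ranked, since every step among them stays within the scatter. No measurement at hand offers an explanation for this result.

On these data alone, all three compounds carry a pyridine ring at this place, so what a phenyl ring, an amine or a carboxylic acid would give there remains open. As far as these compounds go, whether the three pyridinyl groups would also stand level on a different core remains open too.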